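Phenylethyl replacing bromobenzyl on the ring nitrogen

The compounds below may be only part of what the source reports. "The series", "measured", "known", "first", "only" and "open" are said of these compounds alone.

The three measured compounds share one core and differ only in the group on an amine nitrogen in a ring. Compound 1 `CCCn1c(=O)[nH]c2nc(-c3ccc(S(=O)(=O)N4CCN(c5ccc(I)cc5)CC4)cc3)[nH]c2c1=O` carries 4-iodophenyl there; in an assay on CHO cells for displacement of a labelled ligand from adenosine receptor A3 (Homo sapiens), read by scintillation counting, with a stated time of 45 min, tested at 1 uM, in the presence of a further agent that is not named here (on this read-out lower numbers stand for less inhibition and higher numbers for more inhibition at the one concentration tested (going by the name of the read-out)), compound 1 gives 36%. Compound 2 `CCCn1c(=O)[nH]c2nc(-c3ccc(S(=O)(=O)N4CCN(c5ccccc5C)CC4)cc3)[nH]c2c1=O` carries 2-methylphenyl and gives 25%, while compound 3 `CCCn1c(=O)[nH]c2nc(-c3ccc(S(=O)(=O)N4CCN(Cc5cccc(Br)c5)CC4)cc3)[nH]c2c1=O` carries 3-bromobenzyl and gives 23%. Compound 3 thus stands lowest of the three, though its gap to compound 2 is within the scatter: the step of a number 2 percentage points lower from compound 2 to compound 3 (within the scatter) is small, whereas a number 11 percentage points lower from compound 1 to compound 2 (beyond the scatter) and a number 13 percentage points lower from compound 1 to compound 3 (beyond the scatter) are both beyond it.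

Compound 4 `CCCn1c(=O)[nH]c2nc(-c3ccc(S(=O)(=O)N4CCN(C(C)c5ccccc5)CC4)cc3)[nH]c2c1=O` is not yet measured. It differs from compound 3 in one place: 1-phenylethyl in place of 3-bromobenzyl on an amine nitrogen in a ring. Among the measured compounds shown here, the step that bears most directly on this change is the one from compound 2 to compound 3, where a benzyl-type group took the place of an aryl group with little effect, a number 2 percentage points lower from compound 2 to compound 3 (within the scatter). Nothing in the measured set separates a 1-phenylethyl from a 3-bromobenzyl, so no shift beyond the scatter is expected. The step of a number 1 percentage points lower from compound 3 to compound 4 (within the scatter) is expected to be within the scatter. For compound 4 the estimate in this assay is 22%, with a range from 10% to 35%.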

Compound 4, a percentage reported as inhibition, at one concentration (the size of the read-out at that concentration, not a potency): 0%
The estimate for compound 4 lay 22 percentage points above the measured number, outside the stated range (below it).
By their numbers in this assay, from the lowest: compound 4; then compounds 3 and 2 (each within the scatter of the next); then compound 1.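

The new result shows that this position on an amine nitrogen in a ring can respond strongly to a change that leaves much of what is counted intact: in this assay the step is a number 23 percentage points lower from compound 3 to compound 4 (beyond the scatter), although 3-bromobenzyl and 1-phenylethyl have the same number of heavy atoms and each has one six-membered aromatic ring of carbon only. The aryl-bearing compounds also stand well apart from 1-phenylethyl, with a number 25 percentage points lower from compound 2 to compound 4 (beyond the scatter) and a number 36 percentage points lower from compound 1 to compound 4 (beyond the scatter), so the closeness of 2-methylphenyl and 3-bromobenzyl does not extend to every group with an aromatic ring at this place. No measurement offered here accounts for the size of these steps.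

The compounds shown leave open whether the step follows from the loss of the bromine or from the different carbon framework of 1-phenylethyl, a question that a plain benzyl group, a 1-(3-bromophenyl)ethyl group or a 2-phenylethyl group could help to separate. They also leave open how these groups would compare at other concentrations, as each number here comes from a single tested concentration.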